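From Compound 2 to Compound 4 in a Cytotoxicity Series

A few compounds are considered here, and "the series" means these few. Any claim that something is new, unique, unknown or untested is made for them only; others in the source may bear on it.

Measured compounds:
compound 1, `CNC(=O)c1cc(Oc2ccc(C(=O)/C=C/c3cccc([N+](=O)[O-])c3)cc2)ccn1`, "not determined" (no result reported)
compound 2, `CNC(=O)c1cc(Oc2ccc(C(=O)/C=C/c3ccc(F)cc3Cl)cc2)ccn1`, 4760 nM
compound 3, `CNC(=O)c1cc(Oc2ccc(/C=C/C(=O)c3ccc(C)cc3)cc2)ccn1`, "not determined" (no result reported)

Three compounds share a common core, yet only one of them carries a number. In a functional assay on PC-3 cells (Homo sapiens) for cytotoxicity, read by MTT assay, with a stated time of 72 h (a higher number here means a weaker inhibitor, a lower number a stronger inhibitor), compound 2 gives 4760 nM, and it is the sole numerical result of the set; compound 1 and compound 3 have no reported value in this assay. Compound 2 therefore stands alone as the reference point, with nothing above or below it to compare against.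

The unmeasured compound 4, `CNC(=O)c1cc(Oc2ccc(C(=O)/C=C/c3ccc(C#N)cc3)cc2)ccn1`, differs from compound 2 in a single place: 4-cyanophenyl in place of 2-chloro-4-fluorophenyl on a double-bonded chain carbon bound to a double-bonded chain carbon. Going by the values given here, no pair of measured compounds differing in one place exists here, so the size of this kind of change in this assay is unknown from the data at hand.

Without a comparable step to lean on, the expectation for compound 4 rests on compound 2 alone, whose value 4760 nM is the only anchor. The step expected from compound 2 to compound 4 is a 1.1-fold higher number from compound 2 to compound 4 (0.02 log units; within the scatter), which is taken to lie within the usual scatter rather than beyond it. Compound 4 is thus estimated at 5000 nM, with a range from 1500 nM to 16000 nM.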

Compound 4, half-maximal inhibitory concentration: 3870 nM
For compound 4 the middle estimate is 1.3-fold (0.11 log units) above the measured one, within the range that was stated.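

Going by these compounds alone, exchanging 2-chloro-4-fluorophenyl for 4-cyanophenyl on a double-bonded chain carbon bound to a double-bonded chain carbon gives, in this assay, a 1.2-fold lower number from compound 2 to compound 4 (0.09 log units; within the scatter) in the first step at this position that can be read at all. The earlier compounds shown here could not show this, as a single number offers no comparison; the pair now shows that this place tolerates the exchange of one substituted phenyl ring for another, including the entry of a triple bond and a hydrogen-bond acceptor, without a change that the assay can separate from scatter. No measurement on hand bears on why the two groups read alike.

Within the data shown here, compound 1 and compound 3 carry no number, so no step to either can be read, and this one pair cannot say whether the same holds for other substituted phenyl rings at this place. The compounds shown also leave open whether an amine, a carboxylic acid or a longer alkyl chain in place of the phenyl ring would move the number beyond the scatter.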